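The source may hold more compounds than are shown below. What is called first, only, known or untested is meant among the compounds shown, and "the series" means these compounds.

The series shares one core, varied so far at a single aromatic carbon. Compound 1 `COC(=O)c1nc(C)n(-c2ccc(C(F)(F)F)cc2)n1` carries trifluoromethyl there, and in a functional assay on NPC-TW01 cells (Homo sapiens) for inhibition, read by MTT assay, with a stated time of 72 h (on this read-out higher numbers stand for weaker inhibition of growth and lower numbers for stronger inhibition of growth), compound 1 gives only a limit, > 100000 nM, reflecting (the limit of > 100000 nM in this assay, at which 1 of the 3 values shown sits). Compound 2 `COC(=O)c1nc(C)n(-c2ccc(OC)cc2)n1`, with methoxy, gives 9920 nM in this assay, the step being an at least 10-fold lower number from compound 1 to compound 2 (1.00 log units; beyond the scatter). Compound 3 `COC(=O)c1nc(C)n(-c2ccc(F)cc2)n1`, with fluoro, gives 15200 nM in this assay, a step of an at least 6.5-fold lower number from compound 1 to compound 3 (0.81 log units; beyond the scatter); set against compound 2 the step is a 1.5-fold higher number from compound 2 to compound 3 (0.19 log units; within the scatter). Compound 3 thus holds the higher of the two measured numbers, but its gap to compound 2 lies within the scatter, so no order between the two is claimed.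

Compound 4 `COC(=O)c1nc(-c2ccc[nH]2)n(-c2ccc(F)cc2)n1` alters a different place: 1H-pyrrol-2-yl in place of methyl on an aromatic carbon. Among the compounds with values here, none of the three measured steps touches this carbon; all concern the substituent at the other aromatic carbon, so no measured step bears directly on the change. With the fluoro substituent of compound 3 retained, the expectation is a step of a 1.3-fold lower number from compound 3 to compound 4 (0.10 log units; within the scatter) in this assay, with no direction anticipated beyond the scatter. Compound 4 is therefore estimated at 12000 nM, within 2500 nM to 60000 nM.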

Compound 4, concentration for 50% growth inhibition: 9580 nM
For compound 4 the middle estimate is 1.3-fold (0.10 log units) above the measured one; measured number inside the range.
By their numbers in this assay, from the lowest: compounds 4, 2 and 3 (each within the scatter of the next). At a limit, above all of these: compound 1.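

Within the data shown here, this is the first reading at the carbon between two ring nitrogen atoms, and with fluoro retained on the other aromatic carbon it gives a 1.6-fold lower number from compound 3 to compound 4 (0.20 log units; within the scatter) in this assay. A single heavy atom gives way there to a group of five heavy atoms that brings an aromatic ring and a hydrogen-bond donor, yet no order between the two compounds can be claimed, so this one exchange does not separate methyl from 1H-pyrrol-2-yl on this read-out. Nothing measured here accounts for that outcome.

Open, going by these compounds, is whether 1H-pyrrol-2-yl gives the same reading alongside methoxy or trifluoromethyl rather than fluoro. Also open, on these data alone, is how this carbon responds to an amine, a longer chain or a six-membered aromatic ring, and how the series responds to a carboxylic acid in place of the methoxycarbonyl group.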